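Changing the Chain End of Compound 3

A few compounds are considered here, and "the series" means these few. Any claim that something is new, unique, unknown or untested is made for them only; others in the source may bear on it.

In a functional assay on MDA-MB-231 cells (Homo sapiens) for antiproliferative activity, read by MTT assay, with a stated time of 48 h (a lower number here means a stronger inhibitor, a higher number a weaker inhibitor), compound 1 `COc1ccc(N(C)c2ccnc(Cl)n2)cc1[N+](=O)[O-]` gives 8120 nM, compound 2 `COc1ccc(N(C)c2ccnc(Cl)n2)cc1O` gives 833 nM, and compound 3 `COc1ccc(N(C)c2ccnc(Cl)n2)cc1OCCCCBr` gives 992 nM. Compound 3 holds the second highest of the three numbers: a 1.2-fold higher number from compound 2 to compound 3 (0.08 log units; within the scatter) is within the scatter, while an 8.2-fold lower number from compound 1 to compound 3 (0.91 log units; beyond the scatter) lies beyond it. Compound 4 `COc1ccc(N(C)c2ccnc(Cl)n2)cc1OCCC[Se]C#N` differs from compound 3 by a group of 3 heavy atoms (1 carbon, 1 nitrogen, 1 selenium; no ring) in place of a group of 2 heavy atoms (1 carbon, 1 bromine; no ring), on a saturated chain carbon, three bonds along the chain from an oxygen on an aromatic ring. Among the measured compounds shown here, no measured step touches this part of the chain; a 1.2-fold higher number from compound 2 to compound 3 (0.08 log units; within the scatter) shows only that adding the whole 4-bromobutyl chain stayed within the scatter, and a 9.7-fold lower number from compound 1 to compound 2 (0.99 log units; beyond the scatter) concerns the nitro group. With nothing bearing directly on the change, the expected step of a 1.1-fold lower number from compound 3 to compound 4 (0.04 log units; within the scatter) is none beyond the scatter. Compound 4 is therefore estimated at 900 nM, with a range from 300 nM to 2700 nM.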

Compound 4, half-maximal inhibitory concentration: 1490 nM
The estimate for compound 4 lay 1.7-fold (0.22 log units) below the measured number; the measured number falls inside the stated range.
By their numbers in this assay, from the lowest: compounds 2, 3 and 4 (each within the scatter of the next); then compound 1.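

In this assay the group of carbon, nitrogen and selenium at this chain end reads much like the bromomethyl it replaces (a 1.5-fold higher number from compound 3 to compound 4 (0.18 log units; within the scatter)), so this position takes the change without a step beyond the scatter. The full chain also stays within the scatter of the free hydroxy compound (a 1.8-fold higher number from compound 2 to compound 4 (0.25 log units; within the scatter)) and keeps its distance from the nitro compound (a 5.4-fold lower number from compound 1 to compound 4 (0.74 log units; beyond the scatter)). Nothing measured here gives a reason for these numbers. On these data alone, whether an amine, a carboxylic acid or a longer chain would read the same at this place remains open.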